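The source may report more compounds than this note shows. Statements on the series, on what has been measured and on what is new or still open speak of the compounds shown alone.

Measured in a functional assay on MCF7 cells (Homo sapiens) for antiproliferative activity, read by CCK-8 assay, with a stated time of 24 h; on this read-out lower numbers stand for stronger inhibition and higher numbers for weaker inhibition:
compound 1 `CN(C)Cc1ccc2nc(NC(=O)N/N=C/c3ccccn3)sc2c1`: > 40000 nM
compound 2 `CCN(CC)Cc1ccc2nc(NC(=O)N/N=C/c3ccccn3)sc2c1`: > 40000 nM
compound 3 `CCN(CC)Cc1ccc2nc(NC(=O)N/N=C(\C)c3cnccn3)sc2c1`: > 40000 nM

Each of these entries is a limit and not a number. Compound 2 therefore has no measured position, only the limit > 40000 nM, and the two other compounds are limits as well. The whole set stands at the limit of > 40000 nM in this assay, at which 3 of the 3 values shown sit.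

The next change leads to compound 4 `CC1CCN(Cc2ccc3nc(NC(=O)N/N=C/c4ccccn4)sc3c2)CC1`: 4-methylpiperidin-1-yl in place of diethylamino on a saturated chain carbon bound to an aromatic carbon. In words, 4-methylpiperidin-1-yl stands in place of diethylamino on a saturated chain carbon bound to an aromatic carbon.

The closest measured change sits at the same place, a step that the two limits leave unreadable from compound 1 to compound 2. The other change is on an amide-type nitrogen, a step that the two limits leave unreadable from compound 2 to compound 3. Going by these compounds, neither has a readable size, so no size can be carried over to the new change, and the direction stays open.

With no number anywhere in the series, compound 4 is expected to remain at the limit in this assay, where compound 2 sits at > 40000 nM. The expected step is a number no higher from compound 2 to compound 4 (the limit leaves the size open), and this estimate carries little weight. For compound 4 the estimated value is 40000 nM, with an expected range from 15000 nM to 80000 nM.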

Compound 4, half-maximal inhibitory concentration: > 40000 nM
Compound 4: only a limit was reported; the forecaster's own chance of this, stated with the estimate: 75%; the middle value sits exactly at the limit.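

Compound 4 gives > 40000 nM, a limit and not a number. No step from compound 1 or compound 2 to compound 4 can be read, and the series stays flat: the limit of > 40000 nM in this assay, at which 4 of the 4 values shown sit.

The compounds shown leave open whether any change at the saturated chain carbon or on the amide-type nitrogen gives a measurable value in this assay.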